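This account rests on a few compounds, and the source may have more. Where it says the series, first, only, none or still open, it means among the compounds named here.

Measured compounds in the series:
- compound 1, `CC1=NC(C)=C(C(=O)O)C(c2cccc(C)c2)/C1=C(\O)OC/C=C/c1ccccc1`: 76 nM
- compound 2, `CC1=NC(C)=C(C(=O)O)C(c2cccc(I)c2)/C1=C(\O)OC/C=C/c1ccccc1`: 13 nM
- compound 3, `CC1=NC(C)=C(C(=O)O)C(c2cccnc2)/C1=C(\O)OC/C=C/c1ccccc1`: 190 nM

All three share the same core and the same ester chain; they differ only in the aryl group on the saturated ring carbon. In a functional assay on thoracic aorta for inhibition of Voltage-gated L-type calcium channel (Rattus norvegicus) (on this read-out higher numbers stand for weaker inhibition and lower numbers for stronger inhibition), compound 3 stands at the highest number of the three. For the measured compounds named here, the step of a 2.5-fold higher number from compound 1 to compound 3 (0.40 log units; beyond the scatter) is modest, the step of a 15-fold higher number from compound 2 to compound 3 (1.16 log units; beyond the scatter) is large, and the step of a 5.8-fold lower number from compound 1 to compound 2 (0.77 log units; beyond the scatter) shows that a halogen on the phenyl ring gives the lowest number in this assay so far.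

Compound 4, `CC1=NC(C)=C(C(=O)O)C(c2ccoc2)/C1=C(\O)OC/C=C/c1ccccc1`, has not yet been measured. It differs from compound 3 in one place: furan-3-yl in place of pyridin-3-yl on a saturated ring carbon. Both groups are aromatic rings with one hetero atom and one hydrogen-bond acceptor, so the change is smaller than either of the measured steps, which each exchanged a phenyl ring carrying a carbon or iodine substituent for the pyridine. Going by the values given here, no measured step exchanges one heteroaromatic ring for another, so the direction rests on the observation that compound 3 gives the weakest inhibition seen and that the substituted phenyl compounds sit lower. The expected step of a 1.4-fold lower number from compound 3 to compound 4 (0.13 log units; within the scatter) is therefore small, downward, and may lie within the scatter. For compound 4 the estimate in this assay is 140 nM, with a range from 40 nM to 500 nM.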

Compound 4, half-maximal inhibitory concentration: 130 nM
The estimate for compound 4 lay 1.1-fold (0.03 log units) above the measured number; the range from low to high includes it.
By their numbers in this assay, from the lowest: compound 2; then compounds 1, 4 and 3 (each within the scatter of the next, the first and the last beyond it).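

In this assay, the five-membered furan-3-yl in place of the six-membered pyridin-3-yl on the saturated ring carbon gives a 1.5-fold lower number from compound 3 to compound 4 (0.16 log units; within the scatter) and so cannot be told apart from the pyridine, which means this position takes either ring, with an oxygen or a nitrogen as its hetero atom, without a readable difference. The furan-3-yl group also stays within the scatter of the 3-methylphenyl group, with a 1.7-fold higher number from compound 1 to compound 4 (0.23 log units; within the scatter) in the same read-out, even though the 3-methylphenyl and pyridin-3-yl groups stand apart beyond it, while a 10-fold higher number from compound 2 to compound 4 (1.00 log units; beyond the scatter) leaves the 3-iodophenyl group of compound 2 clearly separated from all three other aryl groups. No supporting data on these groups are at hand to account for any of these steps.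

Open, on these data alone, is whether chloro or bromo on the phenyl ring would follow the iodo group of compound 2 or the methyl group of compound 1. Also open, as far as these compounds go, is how a thiophene ring, or a saturated ring such as cyclohexyl, would compare with the furan-3-yl group at this carbon.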